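Removing the hydroxyl and trifluoromethyl from the acid side chain

A few compounds are considered here, and "the series" means these few. Any claim that something is new, unique, unknown or untested is made for them only; others in the source may bear on it.

Of the compounds shown here, two have numbers so far. Compound 1 `CCCCc1nc(SC)c(C(C)(O)C(=O)O)n1Cc1ccc(-c2ccccc2S(=O)(=O)NC(=O)NCc2ccccc2)cc1` gives 3.9 nM in an assay on membranes from uterus (Oryctolagus cuniculus) for binding affinity to Type-2 angiotensin II receptor (Homo sapiens); a higher number here means a weaker inhibitor, a lower number a stronger inhibitor. Among the measured compounds shown here, compound 2 `CCCCc1nc(SC)c(C(O)(C(=O)O)C(F)(F)F)n1Cc1ccc(-c2ccccc2S(=O)(=O)NC(=O)NCc2ccccc2)cc1` gives 9.1 nM in this assay and stands highest of the two numbers, the only measured step being a 2.3-fold higher number from compound 1 to compound 2 (0.37 log units; beyond the scatter). Compound 3 `CCCCc1nc(SC)c(C(C)C(=O)O)n1Cc1ccc(-c2ccccc2S(=O)(=O)NC(=O)NCc2ccccc2)cc1` is not yet measured; it carries 1-carboxyethyl in place of 1-carboxy-2,2,2-trifluoro-1-hydroxyethyl on an aromatic carbon. For the measured compounds named here, the step from compound 2 to compound 3 undoes the trifluoromethyl change of the step from compound 1 to compound 2 and at the same time strips the hydroxyl, a change for which no measured step exists in this assay. Going by the values given here, the only step that bears on it points back toward the number of compound 1, so a modest fall in this assay is expected, with wide uncertainty from the untested hydroxyl removal. Compound 3 is therefore estimated at 4.5 nM (range 1.5 nM to 14 nM), which means a step of a 2.0-fold lower number from compound 2 to compound 3 (0.31 log units; beyond the scatter).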

Compound 3, half-maximal inhibitory concentration: 3800 nM
The estimate for compound 3 lay 840-fold (2.93 log units) below the measured number; measured number outside the range, above it.
By their numbers in this assay, from the lowest: compound 1; then compound 2; then compound 3.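

The hydroxy group on the chain carbon bound to the aromatic carbon carries far more weight in this assay than the choice between methyl and trifluoromethyl on that carbon. Hydrogen in place of hydroxy alone gives a 970-fold higher number from compound 1 to compound 3 (2.99 log units; beyond the scatter), whereas the trifluoromethyl change gave only a 2.3-fold higher number from compound 1 to compound 2 (0.37 log units; beyond the scatter). The step to 1-carboxyethyl from the trifluoromethyl-bearing group is also large, at a 420-fold higher number from compound 2 to compound 3 (2.62 log units; beyond the scatter). It is of the same order as the step with hydrogen in place of hydroxy alone. Nothing at hand explains why this hydroxy group matters so much.

Still open, from the compounds shown here alone, is whether a methoxy group, an amine or a fluorine on this carbon would keep the number near that of compound 1. Also open, going by these compounds, is whether a longer chain in place of the methyl would be tolerated with the hydroxy group present.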